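Chlorophenyl position and topoisomerase inhibition in two pyridine analogues

The source may report more compounds than this note shows. Statements on the series, on what has been measured and on what is new or still open speak of the compounds shown alone.

Measured so far:
Compound 1, `Cc1ccsc1-c1cc(-c2ccc(Cl)o2)cc(-c2ccc(Cl)cc2)n1`, 5.1%
Compound 2, `Clc1cccc(-c2cc(-c3ccc(Cl)o3)cc(-c3ccc(Cl)s3)n2)c1`, 13.3%

Compound 2 gives the higher of the two numbers in an assay on isolated protein for inhibition of DNA topoisomerase 1 (Homo sapiens), with a stated time of 30 min, tested at 100 uM (a lower number here means less inhibition, a higher number more inhibition at the concentration tested (going by the name of the read-out)), but its gap to compound 1 lies within the scatter, so the two cannot be told apart. Compound 3, `Clc1ccc(-c2cc(-c3ccc(Cl)o3)cc(-c3ccc(Cl)s3)n2)cc1`, differs from compound 2 in one place: 4-chlorophenyl in place of 3-chlorophenyl on an aromatic carbon. For the measured compounds named here, no measured pair shows what this change does, and the two values so far sit close together at low inhibition. The step is therefore expected to be small, a number 3.3 percentage points lower from compound 2 to compound 3 (within the scatter), with no direction beyond the scatter. Compound 3 is estimated at 10%, within 0% to 25%.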

Compound 3, a percentage reported as inhibition, at one concentration (the size of the read-out at that concentration, not a potency): 2.2%
Estimate against measurement, compound 3: 7.8 percentage points above; the measured number falls inside the stated range.
By their numbers in this assay, from the lowest: compounds 3, 1 and 2 (each within the scatter of the next, the first and the last beyond it).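

Placing 4-chlorophenyl instead of 3-chlorophenyl on the aromatic carbon next to the ring nitrogen gives the first step beyond the scatter in this assay (a number 11.1 percentage points lower from compound 2 to compound 3 (beyond the scatter)), so the change between these two isomeric groups registers even at low inhibition. For the compounds shown here, by contrast, 5-chlorothiophen-2-yl in place of 3-methylthiophen-2-yl gives no separable step (a number 2.9 percentage points lower from compound 1 to compound 3 (within the scatter)). Nothing available here explains the difference between the two chlorophenyl groups. Still open, from the compounds shown here alone, is what an amine or a carboxylic acid on this phenyl ring, in place of the chlorine, would do.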